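Lengthening the alkoxy chain on the shared core

The compounds below may be only part of what the source reports. "The series", "measured", "known", "first", "only" and "open" are said of these compounds alone.

Measured compounds:
Compound 1, `CCCOC1=C(CCC)C(=O)/C(=C(O)/C=C/c2ccccc2)C(=O)C1(CCC)CCC`, gives 1.9 uM.
Compound 2, `CCCC1(CC=C(C)C)C(=O)C(C(=O)/C=C/c2ccccc2)=C(O)C(CCC)(CCC)C1=O`, gives 7.1 uM.
Compound 3, `CCCC1=C(OCC)C(CCC)(CCC)C(=O)/C(=C(O)\C=C\c2ccccc2)C1=O`, gives 4.6 uM.

All three numbers come from a functional assay on A549 cells (Homo sapiens) for antiproliferative activity, read by sulforhodamine B assay, with a stated time of 3 days; a lower number here means that less compound is needed, a higher number that more compound is needed for the effect. Compound 3 has the second highest of the three values: it sits close to compound 2, within the scatter, while compound 1 lies beyond the scatter below it.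

The unmeasured compound 4, `CCCCOC1=C(CCC)C(=O)/C(=C(O)/C=C/c2ccccc2)C(=O)C1(CCC)CCC`, is built from compound 3 by the change (ethyl in place of hydrogen on a saturated chain carbon, two bonds along the chain from an oxygen on an unsaturated carbon). Read one bond further out, this is ethoxy becoming butoxy.

Among the measured compounds shown here, only one measured step touches this change. Going from propoxy to ethoxy, the step of a 2.4-fold higher number from compound 1 to compound 3 (0.38 log units; beyond the scatter) was a modest move upward. Compound 4 runs in the opposite direction and one carbon further, so the expected step in this assay is downward, though whether the trend continues past propoxy or levels off is not shown by any measured pair. The estimated step is therefore a 2.3-fold lower number from compound 3 to compound 4 (0.36 log units; beyond the scatter), and compound 4 is expected to give about 2 uM, with a likely range from 0.9 uM to 4.5 uM.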

Compound 4, concentration for half-maximal effect: 7.1 uM
For compound 4 the middle estimate is 3.6-fold (0.55 log units) below the measured one, outside the stated range (above it).
By their numbers in this assay, from the lowest: compound 1; then compounds 3, 2 and 4 (each within the scatter of the next).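

Going from ethoxy to butoxy does not extend the lower number seen with propoxy: in this assay this change gives a 1.5-fold higher number from compound 3 to compound 4 (0.19 log units; within the scatter) and so the two chains cannot be told apart. The comparison with propoxy is clearer, as the step of a 3.7-fold higher number from compound 1 to compound 4 (0.57 log units; beyond the scatter) joins the step of a 2.4-fold higher number from compound 1 to compound 3 (0.38 log units; beyond the scatter) and leaves propoxy with a lower number than both the shorter ethoxy and the longer butoxy, so across these three chains the number does not move steadily with chain length. Nothing available explains why propoxy stands apart from the other two chains.

With only three chain lengths at this position, the compounds shown leave open whether the lower number with propoxy marks a real, narrow preference or would be matched by other groups of similar size, such as a branched isopropoxy or a cyclopropylmethoxy. They also leave open what a longer chain such as hexyloxy, or a chain ending in an amine or a carboxylic acid, would give in this assay on the same shared core.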